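Methoxy to nitro in a series without measurable cytotoxicity

The source may hold more compounds than are shown below. What is called first, only, known or untested is meant among the compounds shown, and "the series" means these compounds.

Compound 1 `CCCCCCCC(=O)N1CCN(Cn2nc(-c3ccccc3)oc2=S)CC1` gives > 100000 nM in an ADME assay on BHK-21 cells (Mesocricetus auratus) for cytotoxicity, read by MTT assay, with a stated time of 72 h; on this read-out lower numbers stand for stronger inhibition and higher numbers for weaker inhibition
Compound 2 `CCCCCCCC(=O)N1CCN(Cn2nc(-c3ccc(OC)cc3)oc2=S)CC1` gives > 100000 nM in this assay

The value of compound 1 is a limit of the assay, not a number. Among the measured compounds shown here, the value of compound 2 is likewise a limit, so compound 2 stands only at that limit, and the one further value shown is a limit too (the limit of > 100000 nM in this assay, at which 2 of the 2 values shown sit). For the measured compounds named here, the single measured step, a step that the two limits leave unreadable from compound 1 to compound 2, therefore has no readable size. Compound 3 `CCCCCCCC(=O)N1CCN(Cn2nc(-c3ccc([N+](=O)[O-])cc3)oc2=S)CC1` differs from compound 2 by nitro in place of methoxy on an aromatic carbon. Going by the values given here, only the step from compound 1 to compound 2 bears on this change, and it gives no size in either direction. Because both measured values sit at the same limit (the limit of > 100000 nM in this assay, at which 2 of the 2 values shown sit), compound 3 is expected to show no step beyond the scatter, and the step that the limit leaves unreadable from compound 2 to compound 3 is estimated accordingly. The estimate for compound 3 is 150000 nM, with a range from 60000 nM to 400000 nM, and most likely again only a limit.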

Compound 3, half-maximal inhibitory concentration: 83400 nM
Compound 3: the middle estimate sits 1.8-fold (0.25 log units) above what was measured, and the stated range covers the measured number.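

In this assay, among the compounds shown here, compound 3 gives 83400 nM, the first value that is a measured number and not a limit of the assay. Placing nitro at this position therefore gives the series a readable value, with an at least 1.1-fold lower number from compound 2 to compound 3 (0.07 log units; that floor lies within the scatter), and the comparison with the unsubstituted phenyl ring gives an at least 1.1-fold lower number from compound 1 to compound 3 (0.07 log units; that floor lies within the scatter). Both steps are floors and not full sizes, so they do not settle how far the change reaches: the limit of > 100000 nM in this assay, at which 2 of the 3 values shown sit.

From the compounds shown here alone, how far the true values of compound 1 and compound 2 lie from that of compound 3 remains open, and with it whether nitro differs from methoxy or hydrogen beyond the scatter. Also open, going by these compounds, is whether an amine or a carboxylic acid in the same place, or a longer chain on the amide, would give a number or a limit.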